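Swapping a Furan Ring for a Fluorinated Phenyl Ring

The source may hold more compounds than are shown below. What is called first, only, known or untested is meant among the compounds shown, and "the series" means these compounds.

Measured so far:
- compound 1, `CN1C[C@@H](c2ccc(F)cc2)[C@@]2(Cc3ccccc3C2=O)[C@@]12C(=O)Nc1ccccc12`: 21.8%
- compound 2, `CN1C(=O)[C@@]2(c3ccccc31)N(C)C[C@@H](c1ccco1)[C@@]21Cc2ccccc2C1=O`: 8.2%

In a functional assay on the whole organism (strain Wister albino) for inhibition, with Rattus norvegicus as the target, read by paw edema, with stated times of 1 h and 4 h, at a dose of 50 mg/kg by the intraperitoneal route (a lower number here means less inhibition, a higher number more inhibition at the dose given (going by the name of the read-out)), compound 1 gives 21.8%, and in the same test compound 2 gives 8.2%. Of the two numbers, compound 2 stands lowest, and the gap to compound 1 is wider than the usual scatter of this assay, so the two compounds are truly separated. Within the data shown here, no single-point step between them is counted, as they differ in more than one place, so only the two values themselves can be compared.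

Compound 3, `CN1C(=O)[C@@]2(c3ccccc31)N(C)C[C@@H](c1ccc(F)cc1)[C@@]21Cc2ccccc2C1=O`, has not been measured in this assay. It differs from compound 2 in one place: 4-fluorophenyl in place of furan-2-yl on a saturated ring carbon. The entering group is the same 4-fluorophenyl that sits on the saturated ring carbon of compound 1, which gave 21.8%, whereas compound 2 with its furan-2-yl gave 8.2%. On that basis a modest upward step is expected from compound 2 to compound 3, estimated as a number 6.8 percentage points higher from compound 2 to compound 3 (within the scatter), possibly not far beyond the scatter. For compound 3 in this assay, the estimated inhibition is 15%, with a range from 5% to 28%.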

Compound 3, a percentage reported as inhibition, in the whole organism at one dose (the size of the read-out at that dose, not a potency): 25.5%
Compound 3: middle estimate off by 10.5 percentage points, on the low side, within the range that was stated.
By their numbers in this assay, from the lowest: compound 2; then compounds 1 and 3 (each within the scatter of the next).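

In this assay, among these compounds, placing 4-fluorophenyl instead of furan-2-yl on the saturated ring carbon gives a number 17.3 percentage points higher from compound 2 to compound 3 (beyond the scatter), the first clean evidence that the group at this position matters, since compound 1 and compound 2 differ in more than one place. Placing methyl instead of hydrogen on the amide-type nitrogen in a ring gives a number 3.7 percentage points higher from compound 1 to compound 3 (within the scatter), so with 4-fluorophenyl on the saturated ring carbon, that methyl leaves the two compounds indistinguishable in this read-out. Nothing available here explains why the exchange of furan-2-yl for 4-fluorophenyl has the effect it does.

The two groups compared at this position differ in both ring and fluorine, so these compounds cannot show whether the step comes from the six-membered aromatic ring itself or from its fluorine; plain phenyl would separate the two. From the compounds shown here alone, it also remains open how a quite different group on this carbon, such as a 4-methoxyphenyl or a pyridine ring, would behave, and whether the step seen at this single dose would hold at other doses.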